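Changing the sulfonamide aryl group: from biphenyl to naphthalene

The source may report more compounds than this note shows. Statements on the series, on what has been measured and on what is new or still open speak of the compounds shown alone.

Measured so far:
compound 1, `COc1n[nH]c2ncc(-c3cn(-c4c(F)ccc(NS(=O)(=O)c5ccccc5)c4F)nn3)cc12`, 3.8 nM
compound 2, `COc1n[nH]c2ncc(-c3cn(-c4c(F)ccc(NS(=O)(=O)c5cccc(C#N)c5)c4F)nn3)cc12`, 3.3 nM
compound 3, `COc1n[nH]c2ncc(-c3cn(-c4c(F)ccc(NS(=O)(=O)c5cccc(-c6ccccc6)c5)c4F)nn3)cc12`, 4 nM

All three compounds share the same core and differ only in the ring attached to the sulfonyl sulfur. In an assay on Sf9 cells for inhibition of mitogen-activated protein kinase kinase kinase 20 (Homo sapiens), read by ADP-Glo, with a stated time of 30 min (a lower number here means a stronger inhibitor, a higher number a weaker inhibitor), compound 1 gives 3.8 nM, compound 2 gives 3.3 nM and compound 3 gives 4 nM. The number for compound 3 sits at the top end of the three, but the steps of a 1.1-fold higher number from compound 1 to compound 3 (0.02 log units; within the scatter) and a 1.2-fold higher number from compound 2 to compound 3 (0.08 log units; within the scatter) are within the scatter, as is a 1.2-fold lower number from compound 1 to compound 2 (0.06 log units; within the scatter), so the three cannot be told apart in this assay.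

Compound 4, `COc1n[nH]c2ncc(-c3cn(-c4c(F)ccc(NS(=O)(=O)c5ccc6ccccc6c5)c4F)nn3)cc12`, carries a different ring: naphthalen-2-yl in place of 3-phenylphenyl on a sulfonyl sulfur. Both rings are made of carbon only and both are bicyclic aromatic systems, so the change resembles the earlier swaps of hydrogen, cyano and phenyl, none of which moved this assay beyond the scatter. Compound 4 is therefore expected to show no step beyond the scatter, no change at the digits printed from compound 3 to compound 4 (within the scatter), with an estimate of 4 nM and a range from 1.5 nM to 11 nM.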

Compound 4, half-maximal inhibitory concentration: 4.5 nM
Beside the measured number, compound 4's estimate is 1.1-fold (0.05 log units) below it, and the stated range covers the measured number.
By their numbers in this assay, from the lowest: compounds 2, 1, 3 and 4 (each within the scatter of the next).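

The step of a 1.1-fold higher number from compound 3 to compound 4 (0.05 log units; within the scatter) in this assay shows that a second pair of carbon-only aromatic rings can sit on the sulfonyl sulfur, joined in a different way and with fewer heavy atoms, without a change that can be told from the scatter. The comparisons with the smaller rings read the same way: a 1.4-fold higher number from compound 2 to compound 4 (0.13 log units; within the scatter) for naphthalen-2-yl in place of 3-cyanophenyl and a 1.2-fold higher number from compound 1 to compound 4 (0.07 log units; within the scatter) for naphthalen-2-yl in place of phenyl. Nothing available here explains why this position responds so little.

Every ring shown on the sulfonyl sulfur is aromatic and built of carbon, with a nitrile as the only other atoms added. On these data alone, whether an amine, a carboxylic acid or a plain methyl group at this position would shift the number remains open.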